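The compounds below may be only part of what the source reports. "The series", "measured", "known", "first", "only" and "open" are said of these compounds alone.

Compound 1 `NCCCCCOC[C@H]1O[C@@H](OCCc2c[nH]c3ccccc23)[C@H](OCc2ccccc2)[C@@H](OCc2ccccc2)[C@@H]1OCc1ccccn1` gives 890 nM in an assay on isolated protein for binding affinity to somatostatin receptor type 4 (Homo sapiens), read by radioligand binding; a higher number here means a weaker inhibitor, a lower number a stronger inhibitor.
Compound 2 `NCCCCCOC[C@H]1O[C@@H](OCCc2c[nH]c3ccccc23)[C@H](OCc2ccccc2)[C@@H](OCc2ccccc2)[C@@H]1OCc1cnccn1` gives 260 nM in this assay.

Of these two, compound 2 has the lower number, improving on compound 1 by a 3.4-fold lower number from compound 1 to compound 2 (0.53 log units; beyond the scatter). Compound 3 `NCCCCCOC[C@H]1O[C@@H](OCCc2c[nH]c3ccccc23)[C@H](OCc2ccccc2)[C@@H](OCc2ccccc2)[C@@H]1OCc1c[nH]cn1` differs from compound 2 by 1H-imidazol-4-yl in place of pyrazin-2-yl on a saturated chain carbon bound to an oxygen on a saturated carbon. Within the data shown here, the only measured step, a 3.4-fold lower number from compound 1 to compound 2 (0.53 log units; beyond the scatter), exchanged one six-membered aromatic ring for another, so it bears on this change only loosely; no measured step tests a five-membered aromatic ring. Compound 3 is therefore expected to stay close to compound 2, with an estimated step of a 1.2-fold higher number from compound 2 to compound 3 (0.09 log units; within the scatter) that need not exceed the scatter. Compound 3 is estimated at 320 nM, in a range from 100 nM to 1000 nM.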

Compound 3, inhibition constant: 1040 nM
Beside the measured number, compound 3's estimate is 3.3-fold (0.51 log units) below it; the measured number lies above the stated range.
By their numbers in this assay, from the lowest: compound 2; then compounds 1 and 3 (each within the scatter of the next).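

At this position, on a saturated chain carbon bound to an oxygen on a saturated carbon, the five-membered 1H-imidazol-4-yl does not keep what pyrazin-2-yl gained: this assay shows a 4.0-fold higher number from compound 2 to compound 3 (0.60 log units; beyond the scatter). Against pyridin-2-yl it shows a 1.2-fold higher number from compound 1 to compound 3 (0.07 log units; within the scatter), so these two rings cannot be told apart here. Nothing available explains either step.

Ring size and hydrogen-bond donor count change together in this swap, so their contributions remain unseparated. A 1-methylimidazol-4-yl group or a plain phenyl ring at this place would remain to be compared.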